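Two hydroxycinnamic esters and a closer catechol relative

The source may hold more compounds than are shown below. What is called first, only, known or untested is meant among the compounds shown, and "the series" means these compounds.

Measured so far:
compound 1 `COc1cc(CCC(=O)OCCc2ccc(O)c(O)c2)ccc1O` — 5370 nM
compound 2 `CC(=O)Oc1cc(CCOC(=O)CCc2ccc(O)c(OC(C)=O)c2)ccc1O` — 8470 nM

Of the compounds shown here, two have been tested in a functional assay on C6 cells (Rattus norvegicus) for inhibition, read by sulforhodamine B assay, with a stated time of 72 h; a higher number here means a weaker inhibitor, a lower number a stronger inhibitor. Compound 1 gives 5370 nM, and compound 2 gives 8470 nM. The gap between these two numbers lies within the usual scatter of repeated measurements, so the data do not tell which of the two is the stronger inhibitor; both sit in the same moderate range.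

Compound 3 `O=C(CCc1ccc(O)c(O)c1)OCCc1ccc(O)c(O)c1` has not yet been measured in this assay. It differs from compound 1 in one place: hydrogen in place of methyl on an oxygen on an aromatic ring. The result is that both aromatic rings of compound 3 carry two free hydroxy groups, whereas compound 1 carries a methoxy on one of them. Among the measured compounds shown here, no pair of measured compounds shows the effect of this particular change, so the expectation rests on the change alone. A small step is expected, towards a lower number, of about a 1.4-fold lower number from compound 1 to compound 3 (0.15 log units; within the scatter), though a step of this size would still lie close to the scatter. The estimate for compound 3 in this assay is therefore 3800 nM, with a likely range from 1500 nM to 10000 nM.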

Compound 3, half-maximal inhibitory concentration: 6160 nM
Compound 3: middle estimate off by 1.6-fold (0.21 log units), on the low side; the measured number falls inside the stated range.
By their numbers in this assay, from the lowest: compounds 1, 3 and 2 (each within the scatter of the next).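

Among the compounds shown here, this is the first pair of measured compounds that differ in one place, so it isolates the change from methoxy to hydroxy on an aromatic ring. In this assay, that change gives a 1.1-fold higher number from compound 1 to compound 3 (0.06 log units; within the scatter), which means that compound 1 and compound 3 cannot be told apart by their numbers, even though compound 3 has a hydrogen where compound 1 has a methyl on that oxygen. For this one pair, then, the methoxy and the hydroxy are interchangeable within the resolution of the assay, and no information is available to explain this result.

The compounds shown leave open whether a larger group on the same oxygen, such as an ethyl group or a longer chain, or an amine in place of the hydroxy, would move the number beyond the scatter. For the compounds shown here, they also leave open whether the change from methoxy to hydroxy would give a similar result on a core other than the one shared by this pair, since a single step cannot establish a general pattern.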